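The compounds below may be only part of what the source reports. "The series", "measured", "known", "first", "only" and "open" are said of these compounds alone.

Measured so far in a functional assay on DU-145 cells (Homo sapiens) for antiproliferative activity, read by MTT assay, with a stated time of 72 h; a lower number here means a stronger inhibitor, a higher number a weaker inhibitor:
- compound 1 `O=C(COc1ccc(C(=O)/C=C/c2ccc(Cl)cc2Cl)cc1)N[C@H]1CCOC1=O` gives 8610 nM
- compound 2 `O=C(CNc1ccccc1F)N[C@H]1CCOC1=O` gives only a limit of the assay, > 64000 nM
- compound 3 `CC(C)c1ccc(/C=C/C(=O)c2ccc(OCC(=O)N[C@H]3CCOC3=O)cc2)cc1` gives 13100 nM

Compound 3 and compound 1 sit within the scatter of each other: a 1.5-fold higher number from compound 1 to compound 3 (0.18 log units; within the scatter). Among the measured compounds shown here, the only other value shown, that of compound 2, is a limit and not a number (the limit of > 64000 nM in this assay, at which 1 of the 3 values shown sits). Compound 4 `O=C(COc1ccc(C(=O)/C=C/c2cccc(F)c2)cc1)N[C@H]1CCOC1=O` shares the core of compound 3 and differs from it in one place: 3-fluorophenyl in place of 4-isopropylphenyl on a double-bonded chain carbon bound to a double-bonded chain carbon. For the measured compounds named here, the one measured step that touches this position, the step from compound 1 to compound 3, swaps one aryl group for another and stays within the scatter, so a change of the aryl group at this place has so far left the number where it was. For compound 4 the same is therefore expected in this assay: a step within the scatter, with no clear direction, a 1.3-fold lower number from compound 3 to compound 4 (0.12 log units; within the scatter). The estimate for compound 4 is 10000 nM, with a range from 3500 nM to 30000 nM.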

Compound 4, half-maximal inhibitory concentration: 17200 nM
Compound 4: the middle estimate sits 1.7-fold (0.24 log units) below what was measured; the measured number falls inside the stated range.
By their numbers in this assay, from the lowest: compounds 1, 3 and 4 (each within the scatter of the next). At a limit, above all of these: compound 2.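

The 3-fluorophenyl group, with 7 heavy atoms against 9 in 4-isopropylphenyl, gives a 1.3-fold higher number from compound 3 to compound 4 (0.12 log units; within the scatter) and a 2.0-fold higher number from compound 1 to compound 4 (0.30 log units; within the scatter) in this assay, so this swap leaves the number within the scatter as well. Among the compounds shown here, with two chlorines, an isopropyl group and a single fluorine now compared on the phenyl ring at this place, compound 1, compound 3 and compound 4 still cannot be told apart, a wider finding than the single earlier step could give. No measurement shown gives a reason for this flat picture.

On these data alone, all three groups are substituted phenyl rings, so it remains open whether a phenyl ring carrying an amine or a carboxylic acid at this place would move the number beyond the scatter. As far as these compounds go, whether a longer chain elsewhere on the shared core would do so is also open.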